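The compounds below may be only part of what the source reports. "The series", "measured", "known", "first", "only" and "open" are said of these compounds alone.

Going by the values given here, compound 2, `Cc1ncc([N+](=O)[O-])n1CCOc1ccccc1Cl`, stands at the top of the three numbers so far in a functional assay on HT-29 cells (Homo sapiens) for cytotoxicity, read by MTT assay, with a stated time of 24 h (a higher number here means a weaker inhibitor, a lower number a stronger inhibitor), where compound 2 gives 552 ug/mL. Compound 1, `Cc1ncc([N+](=O)[O-])n1CCOc1ccccc1`, gives 134 ug/mL in this assay, and compound 3, `Cc1ncc([N+](=O)[O-])n1CCOc1ccc(Cl)c(Cl)c1`, gives 109 ug/mL. Among the compounds with values here, the only single-point step among the measured compounds is a 4.1-fold higher number from compound 1 to compound 2 (0.61 log units; beyond the scatter), which put chloro in place of hydrogen on an aromatic carbon and raised the number.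

The next compound, compound 4, `Cc1ncc([N+](=O)[O-])n1CCOc1ccccc1[N+](=O)[O-]`, is reached from compound 2 by nitro in place of chloro on an aromatic carbon, on an aromatic carbon of a six-membered aromatic ring of carbon only, ortho to a large group. Within the data shown here, no measured step exchanges nitro for chloro, so the step from compound 1 to compound 2 is the only one that bears on this change, and it bears only indirectly: it shows that the number at this place moves when the substituent there is altered, and that the unsubstituted compound 1 sits well below compound 2. For compound 4 the number is therefore expected to fall back somewhat toward that of compound 1, giving an expected step of a 1.8-fold lower number from compound 2 to compound 4 (0.26 log units; within the scatter), which may not clear the scatter. The estimate for compound 4 in this assay is 300 ug/mL, with a range from 120 ug/mL to 700 ug/mL.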

Compound 4, half-maximal inhibitory concentration: 581 ug/mL
Beside the measured number, compound 4's estimate is 1.9-fold (0.29 log units) below it, and the stated range covers the measured number.
By their numbers in this assay, from the lowest: compounds 3 and 1 (each within the scatter of the next); then compounds 2 and 4 (each within the scatter of the next).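

In this assay, nitro in place of chloro on an aromatic carbon, ortho to a large group, gives a 1.1-fold higher number from compound 2 to compound 4 (0.02 log units; within the scatter), so this exchange leaves the number within the scatter even though the entering group has more heavy atoms and brings hydrogen-bond acceptors that chloro lacks. Nitro in place of hydrogen at this place gives a 4.3-fold higher number from compound 1 to compound 4 (0.64 log units; beyond the scatter), a step of much the same size as a 4.1-fold higher number from compound 1 to compound 2 (0.61 log units; beyond the scatter), so the rise first seen with chloro now appears with a second, different group, and it is no longer a result of a single substituent. No measurement accompanying these compounds offers an explanation for this result.

The compounds shown leave open whether an amine, a carboxylic acid or a methoxy group at this place would also raise the number to a similar level, or whether any group there would leave it nearer that of the unsubstituted compound 1. They also leave open whether nitro would give a comparable step on another aromatic carbon of this ring.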